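The source may report more compounds than this note shows. Statements on the series, on what has been measured and on what is new or still open speak of the compounds shown alone.

Working notes on the dithiocarbamate series. In a functional assay on HeLa cells (Homo sapiens) for antiproliferative activity, read by CCK-8 assay, with a stated time of 72 h, tested at 2 uM (on this read-out lower numbers stand for a weaker effect and higher numbers for a stronger effect at the one concentration tested), compound 3 `CN(C(=S)SCc1ccc(C(=O)Nc2ccccc2N)cc1)c1cccnc1` gives 16%, which is the lowest of the three numbers in hand. Compound 1 `CC1CCCCN1C(=S)SCc1ccc(C(=O)Nc2ccccc2N)cc1` gives 45.5% and compound 2 `CN(Cc1ccncc1)C(=S)SCc1ccc(C(=O)Nc2ccccc2N)cc1` gives 29.5%; the step of a number 29.5 percentage points lower from compound 1 to compound 3 (beyond the scatter) and the step of a number 13.5 percentage points lower from compound 2 to compound 3 (beyond the scatter) both run downward into compound 3, and a number 16 percentage points lower from compound 1 to compound 2 (beyond the scatter) lies between them, so compound 3 is clearly apart from both.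

Compound 4 `Nc1ccccc1NC(=O)c1ccc(CSC(=S)N2CCCC2)cc1` is the next member: pyrrolidin-1-yl in place of methyl(pyridin-3-yl)amino on a thiocarbonyl carbon. Within the data shown here, the change most relevant here is the one from compound 1 to compound 3, because a number 29.5 percentage points lower from compound 1 to compound 3 (beyond the scatter) covers the swap of a saturated ring amine for the methyl(pyridin-3-yl)amino group on the same thiocarbonyl carbon; run the other way, a saturated ring amine in place of the methyl(pyridin-3-yl)amino group has gone with a modest rise. Pyrrolidin-1-yl is not 2-methylpiperidin-1-yl, and no other step in this assay tests it, so the size is uncertain, but an upward step beyond the scatter is expected. For compound 4 the value in this assay is estimated at 38%, with a range of 22% to 55%, which corresponds to an expected step of a number 22 percentage points higher from compound 3 to compound 4 (beyond the scatter).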

Compound 4, a percentage reported as inhibition, at one concentration (the size of the read-out at that concentration, not a potency): 51.3%
Estimate against measurement, compound 4: 13.3 percentage points below; the measured number falls inside the stated range.
By their numbers in this assay, from the lowest: compound 3; then compound 2; then compounds 1 and 4 (each within the scatter of the next).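

In this assay, the step of a number 5.8 percentage points higher from compound 1 to compound 4 (within the scatter) puts a second saturated ring amine on the thiocarbonyl carbon level with the first, so this read-out does not separate pyrrolidin-1-yl from 2-methylpiperidin-1-yl at this position. The steps of a number 35.3 percentage points higher from compound 3 to compound 4 (beyond the scatter) and a number 21.8 percentage points higher from compound 2 to compound 4 (beyond the scatter) show that the gap between the saturated ring amines and the two pyridine-bearing amines is not confined to 2-methylpiperidin-1-yl: among the four compounds, both saturated ring amines stand beyond the scatter above both pyridine-bearing groups. No supporting data bear on why the saturated ring amines and the pyridine-bearing groups differ in this way.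

The compounds shown leave open whether the lower numbers go with the pyridine ring nitrogen or with the aromatic ring as such, a question that a methyl(phenyl)amino group at the same carbon would address. They also leave open whether the saturated ring amines must be rings at all and whether a further ring nitrogen or oxygen is tolerated, as diethylamino, piperazin-1-yl or morpholin-4-yl groups would show.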